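The source may hold more compounds than are shown below. What is called first, only, known or untested is meant among the compounds shown, and "the series" means these compounds.

Measured compounds:
Compound 1, `CCC(=O)c1cc(-c2ccc(S(N)(=O)=O)cc2)n(-c2ccc(Cl)cc2)n1`: 41900 nM
Compound 2, `CCC(=O)c1cc(-c2ccc(S(N)(=O)=O)cc2)n(-c2cccc(Cl)c2)n1`: 6900 nM
Compound 3, `CCC(=O)c1cc(-c2ccc(S(N)(=O)=O)cc2)nn1-c1ccc(Cl)cc1`: 49600 nM

All three were tested in a physicochemical assay for solubility, read by HPLC, in phosphate buffer, measured as kinetic solubility, at pH 7.4; a higher number here means a more soluble compound, a lower number a less soluble compound. Compound 1 and compound 3 have values within the usual scatter of each other; compound 2 stands apart. The change 3-chlorophenyl in place of 4-chlorophenyl on an aromatic nitrogen gave a 6.1-fold lower number from compound 1 to compound 2 (0.78 log units; beyond the scatter).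

Compound 4, `CCC(=O)c1cc(-c2ccc(S(N)(=O)=O)cc2)nn1-c1cccc(Cl)c1`, has not yet been measured. It differs from compound 3 by 3-chlorophenyl in place of 4-chlorophenyl on an aromatic nitrogen. This is the same kind of change as that from compound 1 to compound 2, but the surroundings differ: here the aromatic nitrogen is next to the ring atom that bears a propanoyl group and two ring bonds from the ring atom that bears a large group, whereas in compound 1 it is next to the ring atom that bears a large group. How the core of compound 3 differs from the core of compound 1 is not broken down here.

Within the data shown here, on that basis, compound 4 is expected to show a 5.8-fold lower number from compound 3 to compound 4 (0.77 log units; beyond the scatter) in this assay, resting on the single step of a 6.1-fold lower number from compound 1 to compound 2 (0.78 log units; beyond the scatter). The estimate for compound 4 is 8500 nM, with a range from 3500 nM to 20000 nM.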

Compound 4, solubility: 700 nM
Beside the measured number, compound 4's estimate is 12-fold (1.08 log units) above it; the whole stated range lies above it.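

In this assay, 3-chlorophenyl in place of 4-chlorophenyl gave a 71-fold lower number from compound 3 to compound 4 (1.85 log units; beyond the scatter), against a 6.1-fold lower number from compound 1 to compound 2 (0.78 log units; beyond the scatter) on the core of compound 1, so the direction carried over from one core to the other, but the size did not. Among these compounds, with only one pair on each core, this does not show that the direction would hold on any further core. Nothing available here explains why the step is larger on the core of compound 3.

From the compounds shown here alone, it remains open whether the same swap would go the same way with a longer chain in place of the propanoyl group. The compounds shown also leave open what an amine or a carboxylic acid in place of the chlorine would do.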